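A few compounds are considered here, and "the series" means these few. Any claim that something is new, unique, unknown or untested is made for them only; others in the source may bear on it.

Compound 2 `O=C(CCc1ccc(C(F)(F)F)cc1)Nc1ccc2nc(N3CCC4(CCNC4)C3)ccc2c1` carries the highest number of the two measured: in a functional assay on HEK293 cells for activation of melanin-concentrating hormone receptor 1 (Rattus norvegicus), read by inositol phosphate accumulation (a higher number here means that more compound is needed for the effect, a lower number that less compound is needed), compound 2 gives 140 nM, while compound 1 `O=C(CCc1ccc(C(F)(F)F)cc1)Nc1ccc2nc(N3CCC3)ccc2c1` gives 56 nM. Among the measured compounds shown here, the only measured step is a 2.5-fold higher number from compound 1 to compound 2 (0.40 log units; beyond the scatter). Compound 3 `O=C(CCc1ccc(C(F)(F)F)cc1)Nc1ccc2nc(N3CC4CCC3CC4)ccc2c1` is reached by the change (a group of 8 heavy atoms (7 carbon, 1 nitrogen; 2 six-membered non-aromatic rings with 1 hetero atom each) in place of a group of 9 heavy atoms (7 carbon, 2 nitrogen; 2 five-membered non-aromatic rings with 1 hetero atom each), on an aromatic carbon). That step bears only loosely on the one that was measured: the step from compound 1 to compound 2 enlarged the amine on the same aromatic carbon and raised the number modestly, whereas the step to compound 3 keeps a similar count of atoms but trades the two five-membered rings for two six-membered ones and gives up the hydrogen-bond donor. For the measured compounds named here, no measured pair tells how such a trade plays out here. Compound 3 is therefore expected to change little beyond the scatter in this assay, with a 1.6-fold lower number from compound 2 to compound 3 (0.19 log units; within the scatter) as the estimated step. The estimate for compound 3 is 90 nM, within a range from 25 nM to 320 nM.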

Compound 3, half-maximal effective concentration: 190 nM
Beside the measured number, compound 3's estimate is 2.1-fold (0.32 log units) below it, and the stated range covers the measured number.
By their numbers in this assay, from the lowest: compound 1; then compounds 2 and 3 (each within the scatter of the next).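

At this position, next to the ring nitrogen, the exchange gives a 1.4-fold higher number from compound 2 to compound 3 (0.13 log units; within the scatter) in this assay, so the hydrogen-bond donor of the group in compound 2 is not needed to keep the number where it stands. Compared with the four-membered ring, the second large group also gives a 3.4-fold higher number from compound 1 to compound 3 (0.53 log units; beyond the scatter), so among these three compounds both larger groups sit beyond the scatter from compound 1, and none goes against this. Nothing measured bears on why the numbers fall this way.

The compounds shown leave open how a single-ring amine such as piperidine or morpholine, or an open-chain amine such as dimethylamine, would stand on this aromatic carbon. They also leave open whether atom count or ring shape sets the distance from compound 1, since both change together here.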